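The source may hold more compounds than are shown below. What is called first, only, known or untested is meant among the compounds shown, and "the series" means these compounds.

Of the compounds shown here, two in this set have been tested in a toxicity assay on NIH3T3 cells (Mus musculus) for cytotoxicity, read by resazurin assay; on this read-out higher numbers stand for an effect only at larger amounts of compound and lower numbers for an effect already at smaller amounts. Compound 1 `c1ccc(-c2ccc(Cn3cncc3CNc3ccc(-c4ccccc4)c(-c4ccccc4)c3)cc2)cc1` reaches only the limit of that test, reported as > 10000 nM. Among the compounds with values here, compound 2 `COC(=O)c1ccc(NCc2cncn2Cc2ccccc2N)cc1-c1ccccc1` is the single compound that gives an actual number in this assay, at 25000 nM. Within the data shown here, the value of compound 1 is a limit, (the limit of > 10000 nM in this assay, at which 1 of the 2 values shown sits), and so no step between two measured compounds can be read from these data. Compound 3 `COC(=O)c1ccc(NCc2cncn2Cc2ccc(F)cc2F)cc1-c1ccccc1` has not yet been measured. It differs from compound 2 in one place: 2,4-difluorophenyl in place of 2-aminophenyl on a saturated chain carbon bound to an aromatic nitrogen. With nothing measured to build on, the step of a 1.3-fold lower number from compound 2 to compound 3 (0.10 log units; within the scatter) is expected to be small, without a clear direction, and to fall inside the usual scatter of repeated measurements in this assay. On that basis compound 3 is estimated to give 20000 nM in this assay, with a likely range from 7000 nM to 60000 nM.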

Compound 3, half-maximal effective concentration: > 1000 nM
Compound 3 was reported as a limit (the forecaster's own chance of this, stated with the estimate: 40%); the middle value lies beyond the limit too.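

Within the data shown here, compound 3 gives only a limit in this assay, not a number, and no step from compound 2 to compound 3 can be read. On these data alone, whether 2,4-difluorophenyl in place of 2-aminophenyl shifts the amount of compound needed for cytotoxicity, and in which direction, stays open.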